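Working notes: methoxy in place of hydrogen on compound 1

This account rests on a few compounds, and the source may have more. Where it says the series, first, only, none or still open, it means among the compounds named here.

Results so far in a functional assay on KB cells (Homo sapiens) for antiproliferative activity, read by MTT assay, with a stated time of 72 h; on this read-out lower numbers stand for stronger inhibition and higher numbers for weaker inhibition
- compound 1 (`O=C(Nc1ccccc1)C(Cl)Cl`): "not determined" (no result reported)
- compound 2 (`N#Cc1cccc(NC(=O)C(Cl)Cl)c1`): 60900 nM

Compound 1 has no single number to stand on, as its entry in this assay reads "not determined" (no result reported) and so gives no baseline. The next analogue is compound 3 (`COc1ccc(NC(=O)C(Cl)Cl)cc1`), reached by methoxy in place of hydrogen on an aromatic carbon. Within the data shown here, no measured step shows the effect of this change, so no shift beyond the scatter is expected in this assay. Among the measured compounds shown here, the only anchor is compound 2 at 60900 nM, and the expectation stays near that value. Compound 3 is estimated at 75000 nM, with an expected range from 30000 nM to 190000 nM.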

Compound 3, half-maximal inhibitory concentration: 278000 nM
The estimate for compound 3 lay 3.7-fold (0.57 log units) below the measured number; measured number above the stated range.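

Among these compounds, with compound 1 at "not determined" (no result reported) in this assay no step to compound 3 can be read. On these data alone, the effect of methoxy in place of hydrogen on the core of compound 1 stays open, and no supporting evidence bears on the result.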